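This account rests on a few compounds, and the source may have more. Where it says the series, first, only, none or still open, it means among the compounds named here.

Compound 1 `N=c1c(=O)[nH]nc2n1CCN2c1ccccc1Cl` and compound 2 `Cc1ccc(N2CCn3c2n[nH]c(=O)c3=N)cc1` share one core. In a functional assay on T47D cells (Homo sapiens) for cytotoxicity, with a stated time of 72 h, tested at 10 ug/mL (a higher number here means a stronger effect of the compound at the concentration tested, a lower number a weaker effect), compound 1 gives 0%, and compound 2 gives 0%; compound 2 thus stands level with compound 1 at the digits shown, within the scatter. Compound 3 `N=c1c(=O)[nH]nc2n1CCN2c1ccccc1` has not yet been tested in this assay. It differs from compound 2 by hydrogen in place of methyl on an aromatic carbon. Going by the values given here, no step between measured compounds is available from which a size could be read, and the two values shown give no sign of movement, so the step of no change at the digits printed from compound 2 to compound 3 (within the scatter) is expected to stay within the scatter. Compound 3 is therefore estimated at 0% in this assay, between 0% and 12%.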

Compound 3, a percentage reported as inhibition, at one concentration (the size of the read-out at that concentration, not a potency): 0%
Compound 3: middle estimate and measured number agree at the digits printed, within the range that was stated.
By their numbers in this assay, from the lowest: compounds 1, 2 and 3 (each within the scatter of the next).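

In this assay, hydrogen in place of methyl on an aromatic carbon, para to a large group, gives no change at the digits printed from compound 2 to compound 3 (within the scatter), and taking away the chloro group gives no change at the digits printed from compound 1 to compound 3 (within the scatter). Compound 3 reads 0%, so the ring without either group reads the same as the methyl and chloro compounds, and neither group brings a read-out at this concentration. No measurement bears on the reason for this. As far as these compounds go, whether an amine, a carboxylic acid or a longer chain on this aromatic carbon would raise the read-out stays open. With all three compounds at the same value, these data cannot show what any group would lower.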